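Swapping 4-chlorophenyl for an indole on the shared core

The compounds below may be only part of what the source reports. "The series", "measured", "known", "first", "only" and "open" are said of these compounds alone.

Measured in a functional assay on A549 cells (Homo sapiens) for inhibition, read by CCK-8 assay, with a stated time of 48 h; on this read-out higher numbers stand for weaker inhibition and lower numbers for stronger inhibition:
- Compound 1 `COc1cc(-c2ccnc3cc(-c4ccc(Cl)cc4)nn23)cc(OC)c1OC`: 3070 nM
- Compound 2 `Cn1ccc2cc(-c3cc4nccc(-c5ccc(F)cc5)n4n3)ccc21`: 3520 nM
- Compound 3 `COc1cc(-c2ccnc3cc(-c4cccc(C#N)c4)nn23)cc(OC)c1OC`: > 10000 nM (a limit of the assay, not a number)

Compound 1 and compound 2 lie within the scatter of each other, so compound 1 sits level with the better of the measured numbers. Compound 4 `COc1cc(-c2ccnc3cc(-c4ccc5cc[nH]c5c4)nn23)cc(OC)c1OC` carries 1H-indol-6-yl in place of 4-chlorophenyl on an aromatic carbon. Within the data shown here, only one measured step bears on this change. Putting 3-cyanophenyl at that same place gave an at least 3.2-fold higher number from compound 1 to compound 3 (0.51 log units; beyond the scatter). That step shows the number can move with the group here, but a different group may move it either way, so a modest drop in this assay is expected, with wide uncertainty. The expected step is a 3.1-fold lower number from compound 1 to compound 4 (0.49 log units; beyond the scatter). For compound 4 the estimated value is 1000 nM, with an expected range of 80 nM to 8000 nM.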

Compound 4, half-maximal inhibitory concentration: 170 nM
Compound 4: middle estimate off by 5.9-fold (0.77 log units), on the high side; the measured number falls inside the stated range.
By their numbers in this assay, from the lowest: compound 4; then compounds 1 and 2 (each within the scatter of the next). At a limit, above all of these: compound 3.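

In this assay, the group on this aromatic carbon can strengthen inhibition as well as weaken it: 1H-indol-6-yl gives an 18-fold lower number from compound 1 to compound 4 (1.26 log units; beyond the scatter). Set against 3-cyanophenyl, the same group gives an at least 58-fold lower number from compound 3 to compound 4 (1.76 log units; beyond the scatter). The size of that second step is only a bound, as compound 3 stands at a limit of the assay and not at a number: the limit of > 10000 nM in this assay, at which 1 of the 4 values shown sits.

The compounds shown leave open whether the indole's ring hydrogen on nitrogen matters, or whether any second fused ring would serve. Also open, on these data alone, is how an aminophenyl or a carboxylic acid would fare at this place.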